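Chain extension on the acylamino group and cytotoxic potency

The compounds below may be only part of what the source reports. "The series", "measured", "known", "first", "only" and "open" are said of these compounds alone.

Compound 3 `CCCCCCCCCCCC(=O)Nc1ccn([C@@H]2CO[C@H](CO)O2)c(=O)n1` gives the lowest number among the three measured compounds in a functional assay on A549 cells (Homo sapiens) for cytotoxicity, read by sulforhodamine B assay, with a stated time of 72 h (a lower number here means a stronger inhibitor, a higher number a weaker inhibitor), with 15 nM. Compound 1 `CCCCC(=O)Nc1ccn([C@@H]2CO[C@H](CO)O2)c(=O)n1` gives 5230 nM and compound 2 `CCCCCCC(=O)Nc1ccn([C@@H]2CO[C@H](CO)O2)c(=O)n1` gives 1040 nM. Compound 4 `CCCCCCCCCCCCCCCCCCCC(=O)Nc1ccn([C@@H]2CO[C@H](CO)O2)c(=O)n1` differs from compound 3 by octyl in place of hydrogen on a saturated chain carbon, ten or more bonds along the chain from a carbonyl carbon. Among the compounds with values here, the steps that bear on this are a 5.0-fold lower number from compound 1 to compound 2 (0.70 log units; beyond the scatter), a 69-fold lower number from compound 2 to compound 3 (1.84 log units; beyond the scatter) and a 350-fold lower number from compound 1 to compound 3 (2.54 log units; beyond the scatter), each a lengthening of the same chain that lowered the number. No measured compound carries a chain longer than that of compound 3, so whether this trend continues is not shown. A smaller step downward in this assay is expected, a 1.5-fold lower number from compound 3 to compound 4 (0.18 log units; within the scatter). Compound 4 is therefore estimated at 10 nM, within a range of 1.5 nM to 120 nM.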

Compound 4, half-maximal inhibitory concentration: 30 nM
Estimate against measurement, compound 4: 3.0-fold (0.48 log units) below, and the stated range covers the measured number.
By their numbers in this assay, from the lowest: compounds 3 and 4 (each within the scatter of the next); then compound 2; then compound 1.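

In this assay, octyl in place of hydrogen on a saturated chain carbon, ten or more bonds along the chain from a carbonyl carbon, gives a 2.0-fold higher number from compound 3 to compound 4 (0.30 log units; within the scatter) and so adds no clear change. The clear falls seen over the shorter chains therefore do not carry on to this length, and the two longest chains cannot be told apart. Nothing measured here explains this.

Still open, as far as these compounds go, is whether a chain of intermediate length would differ from compound 3 or compound 4, or whether a longer chain would raise the number. Also open, from the compounds shown here alone, is how an amine or a carboxylic acid on the chain would compare.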